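The source may hold more compounds than are shown below. What is called first, only, known or untested is meant among the compounds shown, and "the series" means these compounds.

Measured so far in an assay on CHO cells for displacement of a labelled ligand from adenosine receptor A3 (Homo sapiens), read by scintillation counting, tested at 1 uM; a higher number here means more inhibition at the concentration tested (going by the name of the read-out), a lower number less inhibition:
compound 1 `CC(C)Cc1nc(N)c2nn(-c3ccccc3)cc2n1` gives 13%;
compound 2 `Cc1cccc(Cc2nc(N)c3nn(-c4ccccc4)cc3n2)c1` gives 11%;
compound 3 `Nc1nc(Cc2ccccc2Cl)nc2cn(-c3ccccc3)nc12` gives 22%.

Compound 1 stands second highest of these three numbers in this assay; the two neighbouring results show a number 2 percentage points lower from compound 1 to compound 2 (within the scatter) and a number 9 percentage points higher from compound 1 to compound 3 (within the scatter), neither of which separates from the scatter. Compound 4 `Nc1nc(CCCc2ccccc2)nc2cn(-c3ccccc3)nc12` differs from compound 1 by phenethyl in place of isopropyl on a saturated chain carbon bound to an aromatic carbon. The two earlier replacements of isopropyl by an aromatic group on this chain carbon bear on this step, and both stayed within the scatter; only a number 11 percentage points higher from compound 2 to compound 3 (beyond the scatter) reached a modest size. A step of about a number 3 percentage points higher from compound 1 to compound 4 (within the scatter) in this assay is therefore expected, not beyond the scatter. Compound 4 is estimated at 16%, with a range from 4% to 30%.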

Compound 4, a percentage reported as inhibition, at one concentration (the size of the read-out at that concentration, not a potency): 12%
The estimate for compound 4 lay 4 percentage points above the measured number; the measured number falls inside the stated range.
By their numbers in this assay, from the lowest: compounds 2, 4, 1 and 3 (each within the scatter of the next, the first and the last beyond it).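

In this assay, phenethyl gives a number 1 percentage points lower from compound 1 to compound 4 (within the scatter) and a number 1 percentage points higher from compound 2 to compound 4 (within the scatter), so this larger group, with its aromatic ring, does not separate from isopropyl or 3-methylphenyl. Set against 2-chlorophenyl, it gives a number 10 percentage points lower from compound 3 to compound 4 (within the scatter), so none of the three new steps leaves the scatter. No measurement shown gives a reason for this.

These numbers come from a single concentration, so they are not potencies. Going by these compounds, whether an amine or a carboxylic acid on this chain carbon would move the number beyond the scatter remains open.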